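Pyrazolyl for acetylpiperidinyl on the shared core

The source may report more compounds than this note shows. Statements on the series, on what has been measured and on what is new or still open speak of the compounds shown alone.

Compound 1 `CC(=O)N1CCC(c2cnc(NCc3c(F)ccc4c3CCO4)c3cn[nH]c(=O)c23)CC1` is the starting point, measured in a physicochemical assay for solubility, read by LC-MS, in phosphate buffer, with a stated time of 24 h, at pH 7.4; a higher number here means a more soluble compound, a lower number a less soluble compound. In this assay compound 1 gives only a limit, < 2000 nM. Compound 2 `O=C(Nc1cnc(NCc2c(F)ccc3c2CCO3)n2cnnc12)c1ccccc1` gives 2000 nM in this assay. Among the compounds with values here, no step between measured compounds can be drawn here; compound 1 sits at the limit of < 2000 nM in this assay, at which 1 of the 2 values shown sits. Compound 3 `Cc1nn(C)cc1-c1cnc(NCc2c(F)ccc3c2CCO3)c2cn[nH]c(=O)c12` carries 1,3-dimethyl-1H-pyrazol-4-yl in place of 1-acetylpiperidin-4-yl on an aromatic carbon on the core of compound 1. The step from compound 1 to compound 3 is expected to be small, within the scatter, a step that the limit leaves unreadable from compound 1 to compound 3. Compound 3 is therefore expected at 1500 nM, between 500 nM and 4000 nM, and may again come back as a limit.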

Compound 3, solubility: 9000 nM
Estimate against measurement, compound 3: 6.0-fold (0.78 log units) below; the whole stated range lies below it.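

Within the data shown here, on an aromatic carbon of the shared core, 1,3-dimethyl-1H-pyrazol-4-yl in place of 1-acetylpiperidin-4-yl gives the first readable step at this position in this assay (an at least 4.5-fold higher number from compound 1 to compound 3 (0.65 log units; beyond the scatter)). Compound 3 returns a number rather than a limit, so the change is shown to raise the read-out beyond the scatter. The true size of the step stays unknown, since its lower end rests on a limit: the limit of < 2000 nM in this assay, at which 1 of the 3 values shown sits.

The compounds shown do not separate the effect of the aromatic ring from that of its methyl groups. An unsubstituted 1H-pyrazol-4-yl or a piperidin-4-yl with a free amine would bear on that question.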